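This account rests on a few compounds, and the source may have more. Where it says the series, first, only, none or still open, it means among the compounds named here.

Compound 1, `COc1ccc2c(=O)c(/C=C/C(=O)Nc3cc(C)ccc3C)coc2c1`, is the reference point of this account. In a functional assay on L02 cells (Homo sapiens) for inhibition, read by MTT assay, with a stated time of 48 h (on this read-out higher numbers stand for weaker inhibition and lower numbers for stronger inhibition), compound 1 reaches only the limit of the measurement, > 200000 nM, and no number is known for it. Compound 2, `COc1ccc2c(=O)c(/C=C/C(=O)NCc3ccccc3)coc2c1`, differs from it by a benzyl in place of a 2,5-dimethylphenyl on the amide-type nitrogen. In this assay compound 2 likewise gives only a limit, > 200000 nM. Compound 3, `COc1ccc(NC(=O)/C=C/c2coc3cc(OC)ccc3c2=O)cc1`, carries a 4-methoxyphenyl on that nitrogen instead. In this assay compound 3 again stops at a limit, > 200000 nM. The steps among these three compounds are consequently not readable: a step that the two limits leave unreadable from compound 1 to compound 2, a step that the two limits leave unreadable from compound 1 to compound 3 and a step that the two limits leave unreadable from compound 2 to compound 3. What the three share is the limit of > 200000 nM in this assay, at which 3 of the 3 values shown sit.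

Compound 4, `COc1ccc2c(=O)c(/C=C/C(=O)Nc3cccc(C)c3)coc2c1`, is the compound still to be measured. It differs from compound 1 by hydrogen in place of methyl on an aromatic carbon. Among the compounds with values here, none of the measured steps can be read in size or direction, and every one of them, like this one, alters the group on the amide-type nitrogen. Within the data shown here, nothing among the measured compounds points toward compound 4 leaving the limit. Compound 4 is therefore expected to sit at 300000 nM, within a range from 150000 nM to 1000000 nM in this assay. The step this estimate implies, a step that the limit leaves unreadable from compound 1 to compound 4, is expected to be no more than scatter, with a limit rather than a number the most likely outcome.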

Compound 4, half-maximal inhibitory concentration: > 200000 nM
Compound 4: a limit, no number; the forecaster's own chance of this, stated with the estimate: 85%; the middle value is on the limit's open side.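

Compound 4 also stops at a limit, so the steps to it from compound 1, compound 2 and compound 3 cannot be read in this assay: the limit of > 200000 nM in this assay, at which 4 of the 4 values shown sit.

The compounds shown leave open whether any change to the group on the amide-type nitrogen would bring a value off this limit, and what number each of the four compounds would give.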